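Oxan-4-yl in place of cyclohexyl: expected maximal response

This account rests on a few compounds, and the source may have more. Where it says the series, first, only, none or still open, it means among the compounds named here.

Measured so far:
compound 1 `Cc1cc(NC(=O)Cn2nnc(-c3ccccc3)n2)n(C2CCCCC2)n1`: 92%
compound 2 `Cc1cc(NC(=S)Cn2nnc(-c3ccccc3)n2)n(C2CCCCC2)n1`: 80%

In an assay on HEK293 cells for activation of Kir3.1/Kir3.2 (Homo sapiens), read by thallium flux (on this read-out higher numbers stand for larger maximal responses and lower numbers for smaller maximal responses), compound 1 stands highest of the two measured compounds; compound 2 lies lower by a gap beyond the usual scatter. Compound 3 `Cc1cc(NC(=O)Cn2nnc(-c3ccccc3)n2)n(C2CCOCC2)n1` differs from compound 1 by oxan-4-yl in place of cyclohexyl on an aromatic nitrogen. Among the measured compounds shown here, no measured pair shows this change, so the step in this assay from compound 1 to compound 3 is expected to be small, either within the scatter or a modest fall in maximal response. Compound 3 is expected to give 84% in this assay, with a range from 65% to 100%. This estimate corresponds to a step of a number 8 percentage points lower from compound 1 to compound 3 (within the scatter).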

Compound 3, largest response reached (Emax), in percent of the reference or control that the assay uses: 115%
Beside the measured number, compound 3's estimate is 31 percentage points below it; measured number above the stated range.
By their numbers in this assay, from the lowest: compound 2; then compound 1; then compound 3.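

In this assay, the position on the aromatic nitrogen does not need a ring of carbon only: oxan-4-yl in place of cyclohexyl gives a rise of a number 23 percentage points higher from compound 1 to compound 3 (beyond the scatter), beyond the scatter. The heavy-atom count stays the same while the ring gains a hetero atom and a hydrogen-bond acceptor, so this position responds to a swap of one ring atom. Nothing on hand explains the rise. From the compounds shown here alone, whether a ring nitrogen, as in piperidin-4-yl, or a methoxy-bearing chain would match oxan-4-yl stays open. So does whether the same change would raise compound 2.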